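Bromine in Place of the Sulfoxide Chain

The source may hold more compounds than are shown below. What is called first, only, known or untested is meant among the compounds shown, and "the series" means these compounds.

Of the compounds shown here, three sharing one core have been measured in a functional assay on the whole organism (stomach) for inhibition, with Canis familiaris (Canis lupus familiaris) as the target, at a dose of 5 mg/kg by the intravenous route; a higher number here means a stronger effect of the compound at the dose given, a lower number a weaker effect. Compound 1 `CC(=O)c1c(C)nc2c(OCc3ccccc3)cccn12` gives 9%, compound 2 `CSCc1c(C)nc2c(OCc3ccccc3)cccn12` gives 8%, and compound 3 `Cc1nc2c(OCc3ccccc3)cccn2c1C[S+](C)[O-]` gives 18%. Compound 3 holds the highest of the three numbers, yet every step among them is small: a number 9 percentage points higher from compound 1 to compound 3 (within the scatter), a number 10 percentage points higher from compound 2 to compound 3 (within the scatter), and a number 1 percentage points lower from compound 1 to compound 2 (within the scatter). Compound 4 `Cc1nc2c(OCc3ccccc3)cccn2c1Br` differs from compound 3 in one place: one bromine atom in place of a group of 4 heavy atoms (2 carbon, 1 oxygen, 1 sulfur; no ring), on an aromatic carbon. For the measured compounds named here, the steps that bear on this change are the two that alter the same aromatic carbon on the way to compound 3, and both stayed within the scatter. Compound 4 is therefore expected to show a number 6 percentage points lower from compound 3 to compound 4 (within the scatter), nothing beyond the scatter. Compound 4 is estimated at 12%, in a range from 0% to 30%.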

Compound 4, a percentage reported as inhibition, in the whole organism at one dose (the size of the read-out at that dose, not a potency): 63%
Compound 4: the middle estimate sits 51 percentage points below what was measured; the whole stated range lies below it.
By their numbers in this assay, from the lowest: compounds 2, 1 and 3 (each within the scatter of the next); then compound 4.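

In this assay, bromo in place of the sulfoxide chain gives a number 45 percentage points higher from compound 3 to compound 4 (beyond the scatter), while bromo gives a number 55 percentage points higher from compound 2 to compound 4 (beyond the scatter) in place of (methylsulfanyl)methyl and a number 54 percentage points higher from compound 1 to compound 4 (beyond the scatter) in place of acetyl. This aromatic carbon, which had looked insensitive while the three earlier groups stayed within the scatter of one another, can therefore carry a large change in the read-out. That change came with the single bromine atom, the smallest group of the four.

From the compounds shown here alone, whether chlorine, iodine or a plain hydrogen on this carbon would do the same remains open. Nothing at hand accounts for the size of the step.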